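Swapping Chlorines for Fluorines on a Saturated Ring Carbon

This account rests on a few compounds, and the source may have more. Where it says the series, first, only, none or still open, it means among the compounds named here.

Measured so far:
Compound 1, `COc1cc(-c2nnc3n2CCCC3(O)c2ccc(Cl)c(Cl)c2)ccc1-c1cnc(C)o1`: 2.9
Compound 2, `COc1cc(-c2nnc3n2CCCC3(c2ccc(Cl)c(Cl)c2)C(C)(C)O)ccc1-c1cnc(C)o1`: 3.7

In a physicochemical assay for lipophilicity, measured as chromatographic lipophilicity, at pH 7.4 (on this read-out higher numbers stand for higher lipophilicity and lower numbers for lower lipophilicity), compound 2 gives 3.7, the higher of the two numbers, while compound 1 gives 2.9. Going by the values given here, the only measured step, a number 0.80 log units higher from compound 1 to compound 2 (beyond the scatter), concerns a different group and so does not bear on the change at hand. Compound 3, `COc1cc(-c2nnc3n2CCCC3(c2ccc(F)c(F)c2)C(C)(C)O)ccc1-c1cnc(C)o1`, differs from compound 2 in one place: 3,4-difluorophenyl in place of 3,4-dichlorophenyl on a saturated ring carbon. Among the compounds with values here, no measured step covers this exchange, so the expectation rests on the structural change alone. A downward step, a number 0.90 log units lower from compound 2 to compound 3 (beyond the scatter), is expected in this assay. Compound 3 is estimated at 2.8, in a range from 2.3 to 3.3.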

Compound 3, distribution coefficient: 2.9
Compound 3: the middle estimate sits 0.10 log units below what was measured; low and high end bracket the measured number.
By their numbers in this assay, from the lowest: compounds 1 and 3 (each within the scatter of the next); then compound 2.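

In this assay, 3,4-difluorophenyl in place of 3,4-dichlorophenyl on a saturated ring carbon gives a number 0.80 log units lower from compound 2 to compound 3 (beyond the scatter). Going by these compounds alone, the earlier compounds changed only the hydroxy-bearing group on this carbon, so this is the first sign that the read-out also responds to the halogens on the aromatic group held there. Nothing available explains the size of this step. As far as these compounds go, it remains open whether the exchange gives a similar step when hydroxy replaces 1-hydroxy-1-methylethyl. From the compounds shown here alone, how an unsubstituted phenyl or a pyridine ring would read at this place is also open.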